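The compounds below may be only part of what the source reports. "The series", "measured", "known", "first", "only" and "open" are said of these compounds alone.

Two compounds share one core and differ only in the group carried on one of the two benzyl arms. Compound 1 `COc1ccc(Cn2c(NCCNC(=N)N)nc(=O)n(Cc3ccc(F)cc3)c2=O)cc1` carries a fluoro group there, and in a functional assay on the whole organism (strain C57Bl/6) for inhibition, with Mus musculus as the target, with a stated time of 180 min, at 48 degrees C (on this read-out lower numbers stand for an effect already at smaller amounts and higher numbers for an effect only at larger amounts of compound), compound 1 gives 0.00031 nM. Compound 2 `COc1ccc(Cn2c(=O)nc(NCCNC(=N)N)n(Cc3ccc(C(F)(F)F)cc3)c2=O)cc1` carries a trifluoromethyl group in the same spot, and in this assay compound 2 gives 0.048 nM. Within the data shown here, of the two numbers measured so far, compound 2 has the higher one, so it needs more material for the same effect, and its gap to compound 1 lies well beyond the usual scatter of repeated measurements.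

Compound 3 `COc1ccc(Cn2c(=O)nc(NCCNC(=N)N)n(Cc3ccc(Br)cc3)c2=O)cc1` has not yet been measured. It differs from compound 2 in one place: bromo in place of trifluoromethyl on an aromatic carbon. Compound 1 and compound 2 show that a change of this group on this ring can move the number a long way, but a single pair gives no rule for the direction a bromo group would take. The step from compound 2 to compound 3 in this assay is expected to be small, a 2.4-fold lower number from compound 2 to compound 3 (0.38 log units; beyond the scatter), toward a slightly lower number. Compound 3 is therefore estimated at 0.02 nM, with a range from 0.003 nM to 0.15 nM.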

Compound 3, half-maximal effective concentration: 0.0043 nM
Estimate against measurement, compound 3: 4.7-fold (0.67 log units) above; low and high end bracket the measured number.
By their numbers in this assay, from the lowest: compound 1; then compound 3; then compound 2.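

Exchanging trifluoromethyl for bromo on this aromatic carbon gives an 11-fold lower number from compound 2 to compound 3 (1.05 log units; beyond the scatter) in this assay, so this spot on the ring responds strongly even to a swap between two small groups. Neither group carries a hydrogen-bond donor, a hydrogen-bond acceptor or a net charge, so the large step arises without any change in those counts; what does change is that four heavy atoms are replaced by a single bromine atom. Nothing available here accounts for the size of this step, so the reason for it remains unknown.

Still open, going by these compounds, is how other groups on this same carbon would read in this assay, such as a plain hydrogen, a methyl group, an amine, a carboxylic acid or a longer alkyl chain, and whether the numbers would then follow any order. Also open, on these data alone, is whether the same exchange of trifluoromethyl for bromo would produce a step of similar size in another setting, such as on the other benzyl arm, since a single pair cannot show how far this result carries.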